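The source may hold more compounds than are shown below. What is called first, only, known or untested is meant among the compounds shown, and "the series" means these compounds.

Measured compounds:
Compound 1, `N#CC1=C(N)Oc2c(c3nc4ccccc4nc3c3ccccc23)C12C(=O)N(Cc1cnnn1-c1ccc(S(N)(=O)=O)cc1)c1ccccc12`: in a functional assay on MCF7 cells (Homo sapiens) for antiproliferative activity, read by MTT assay, with a stated time of 48 h (on this read-out lower numbers stand for stronger inhibition and higher numbers for weaker inhibition), compound 1 reports > 50000 nM, a limit of the assay and not a number.
Compound 2, `N#CC1=C(N)Oc2c(c3nc4ccccc4nc3c3ccccc23)C12C(=O)N(Cc1cnnn1-c1cc(Cl)ccc1Cl)c1ccccc12`: in this assay compound 2 reports > 50000 nM, again a limit.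
Compound 3, `N#CC1=C(N)Oc2c(N)cc3nc4ccccc4nc3c2C12C(=O)N(Cc1cnnn1-c1cccc(Br)c1)c1ccccc12`: in this assay compound 3 reports > 50000 nM, also a limit.

Compound 3 thus stands only at a limit, and the two further values shown sit at the same limit (the limit of > 50000 nM in this assay, at which 3 of the 3 values shown sit). For the measured compounds named here, the single step between measured compounds, a step that the two limits leave unreadable from compound 1 to compound 2, is of unreadable size, both of its ends being limits. Compound 4, `CCc1cccc(C)c1-n1nncc1CN1C(=O)C2(C(C#N)=C(N)Oc3c(N)cc4nc5ccccc5nc4c32)c2ccccc21`, differs from compound 3 by 2-ethyl-6-methylphenyl in place of 3-bromophenyl on an aromatic nitrogen. Going by the values given here, no measured step bears on this exchange, and no compound of the series has yet given a number in this assay. The expectation is therefore that compound 4 stays at the limit, with no step beyond the scatter. The estimated step that the limit leaves unreadable from compound 3 to compound 4 is accordingly set at none. Compound 4 is estimated at 60000 nM, with a range from 20000 nM to 200000 nM, and most likely to be reported only as a limit.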

Compound 4, half-maximal inhibitory concentration: > 50000 nM
Compound 4: no number, only a limit; the forecaster's own chance of this, stated with the estimate: 85%; the middle value does not contradict the limit.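

Compound 3 and compound 4 are both reported only as limits in this assay, and no step can be read between them. The series shares a single limit: the limit of > 50000 nM in this assay, at which 4 of the 4 values shown sit.

The compounds shown leave open whether any exchange on the shared core would give a measurable number.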